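The compounds below may be only part of what the source reports. "The series", "measured", "known", "first", "only" and "open" are said of these compounds alone.

Of the compounds shown here, three sharing one core have been measured for their ability to block the leukotriene receptor. Compound 1 `CCCc1cc(C(C)=O)c(O)cc1OCCCCC#N` gives 37% in an assay on isolated protein for binding affinity to leukotriene B4 receptor 1 (Homo sapiens), tested at 1 uM; a higher number here means more inhibition at the concentration tested (going by the name of the read-out), a lower number less inhibition. Compound 2 `CCCCCCc1cc(C(C)=O)c(O)cc1OCCCCC#N` carries a hexyl chain where compound 1 carries propyl; in this assay compound 2 gives 13%. Compound 3 `CC(=O)c1cc(CO)c(OCCCCCCC#N)cc1O` gives 8%. Among the three numbers, compound 2 stands second highest: compound 3 lies close to it, within the scatter, while compound 1 sits well above it, beyond the scatter.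

The next compound, compound 4 `C=CCc1cc(C(C)=O)c(O)cc1OCCCCC#N`, differs from compound 2 in one place: vinyl in place of pentyl on a saturated chain carbon bound to an aromatic carbon. Going by the values given here, the only measured step that bears on this is the one from compound 1 to compound 2, where lengthening the chain gave a number 24 percentage points lower from compound 1 to compound 2 (beyond the scatter). Compound 4 goes the other way, shortening the chain back to a length close to that of compound 1, so a rise of roughly that size is expected, bringing the number back toward that of compound 1.

Compound 4 is therefore estimated at 32%, with a likely range from 15% to 48%. This estimate means a step of a number 19 percentage points higher from compound 2 to compound 4 (beyond the scatter), which is expected to lie beyond the scatter.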

Compound 4, a percentage reported as inhibition, at one concentration (the size of the read-out at that concentration, not a potency): 57%
Beside the measured number, compound 4's estimate is 25 percentage points below it; measured number above the stated range.
By their numbers in this assay, from the lowest: compounds 3 and 2 (each within the scatter of the next); then compound 1; then compound 4.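

In this assay the chain on this carbon now shows more than a dependence on length: the change from hexyl to allyl gives a number 44 percentage points higher from compound 2 to compound 4 (beyond the scatter) and so more than reverses the fall seen from propyl to hexyl. The comparison with propyl is the more telling one, since vinyl in place of ethyl gives a number 20 percentage points higher from compound 1 to compound 4 (beyond the scatter) and brings in one double bond outside the aromatic ring, so the earlier trend in chain size alone does not describe these three compounds. Nothing shown explains why the compound with the double bond gives the higher number.

From the compounds shown here alone, it remains open whether the double bond itself carries this gain or whether other groups on the same carbon, such as propargyl with its triple bond, a cyclopropylmethyl group or a benzyl group, would do as well or better. Also open, going by these compounds, is whether a longer chain with a double bond would keep the gain or fall away as hexyl did, and how the reading at a single concentration would translate into a true potency.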